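Diphenylacetamide series: amine terminus and sodium channel inhibition

The source may hold more compounds than are shown below. What is called first, only, known or untested is meant among the compounds shown, and "the series" means these compounds.

Measured so far:
compound 1, `CCN(CC)CCCNC(=O)C(c1ccccc1)c1ccccc1`: 4400 nM
compound 2, `O=C(NCCCN1CCC(c2ccccc2)CC1)C(c1ccccc1)c1ccccc1`: 1100 nM

In an assay on CHO cells for inhibition of sodium channel protein type 2 subunit alpha (Rattus norvegicus) (on this read-out lower numbers stand for stronger inhibition and higher numbers for weaker inhibition), compound 1 gives 4400 nM, the higher of the two numbers; compound 2 sits at 1100 nM, a gap beyond the scatter. Compound 3, `O=C(NCCCCN1CCCCC1)C(c1ccccc1)c1ccccc1`, remains to be measured. Compound 3 differs from compound 1 by (piperidin-1-yl)methyl in place of diethylamino on a saturated chain carbon, three bonds along the chain from an amide-type nitrogen. Among the compounds with values here, no step between measured compounds covers this change; compound 2 shows only that a ring-bearing terminus can give a lower number. A modest downward step is expected, a 1.8-fold lower number from compound 1 to compound 3 (0.25 log units; within the scatter), because compound 1 stands at 4400 nM. For compound 3 the estimate is 2500 nM, with a range from 800 nM to 7500 nM.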

Compound 3, half-maximal inhibitory concentration: 10000 nM
The estimate for compound 3 lay 4.0-fold (0.60 log units) below the measured number; the measured number lies above the stated range.
By their numbers in this assay, from the lowest: compound 2; then compound 1; then compound 3.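

In this assay, (piperidin-1-yl)methyl in place of diethylamino on this saturated chain carbon gives a 2.3-fold higher number from compound 1 to compound 3 (0.36 log units; beyond the scatter), so this change goes with weaker inhibition. A saturated six-membered ring at the amine terminus therefore does not by itself bring a lower number. No measured evidence bears on what lies behind this step.

The change can also be read as (diethylamino)methyl to 2-(piperidin-1-yl)ethyl, so the ring and the added chain carbon remain unseparated. Still open, from the compounds shown here alone, is how a plain piperidin-1-yl in place of diethylamino, with no added carbon, or a morpholine terminus would read.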